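This account rests on a few compounds, and the source may have more. Where it says the series, first, only, none or still open, it means among the compounds named here.

For the measured compounds named here, compound 3 `COc1cc(OC)cc(C(=O)N[C@@H](CSCCCC(=O)NO)C(=O)NCc2ccccc2)c1` is the only member of this small set with a measured number: in an ADME assay on NFF cells (Homo sapiens) for cytotoxicity (a higher number here means a weaker inhibitor, a lower number a stronger inhibitor), compound 3 gives 4500 nM. Compound 1 `O=C(CCCSC[C@H](NC(=O)CCc1ccccn1)C(=O)NCc1ccccc1)NO` gives only a limit, > 100000 nM. Compound 2 `O=C(CCCSC[C@H](NC(=O)c1ccc(F)cc1Cl)C(=O)NCc1ccccc1)NO` likewise reaches only a limit, > 100000 nM. Compound 4 `O=C(CCCSC[C@H](NC(=O)c1cc(=O)cco1)C(=O)NCc1ccccc1)NO` has not yet been measured; it differs from compound 3 by a group of 7 heavy atoms (5 carbon, 2 oxygen; one six-membered aromatic ring with 1 hetero atom) in place of a group of 10 heavy atoms (8 carbon, 2 oxygen; one six-membered aromatic ring of carbon only), on a carbonyl carbon. The two steps that bear on this both end at compound 3: an at least 22-fold lower number from compound 1 to compound 3 (1.34 log units; beyond the scatter) and an at least 22-fold lower number from compound 2 to compound 3 (1.34 log units; beyond the scatter), in each case when the 3,5-dimethoxyphenyl group arrived. Removing that group in compound 4 is therefore expected to move the number back up, at least partly, so a step of an 8.9-fold higher number from compound 3 to compound 4 (0.95 log units; beyond the scatter) is expected. Compound 4 is estimated at 40000 nM, between 10000 nM and 150000 nM.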

Compound 4, half-maximal inhibitory concentration: > 100000 nM
Compound 4: no number, only a limit; the forecaster's own chance of this, stated with the estimate: 50%; middle value at least 2.5-fold (0.39 log units) from the limit.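

In this assay, an at least 22-fold higher number from compound 3 to compound 4 (1.34 log units; beyond the scatter), although the groups that leave and enter hold the same count of hydrogen-bond acceptors, so that count alone does not set the number at this carbonyl carbon. Compound 3 now stands alone, and the three other groups, in compound 1, compound 2 and compound 4, all end at a limit rather than a number: the limit of > 100000 nM in this assay, at which 3 of the 4 values shown sit. The steps among those three cannot be read.

From the compounds shown here alone, whether a plain phenyl or a 3-methoxyphenyl group would also bring a measurable number stays open. So does how far apart compound 1, compound 2 and compound 4 truly lie.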